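Methoxy for methyl on the aromatic ring of compound 1

A few compounds are considered here, and "the series" means these few. Any claim that something is new, unique, unknown or untested is made for them only; others in the source may bear on it.

Within the data shown here, compound 1 `COC(=O)[C@@]1(C)CCC=C2[C@@H]1CC[C@@H](C)[C@]2(C)Cc1c[nH]c2ccc(C)cc12` gives 14000 nM in a functional assay on HeLa cells (Homo sapiens) for inhibition, read by sulforhodamine B assay, with a stated time of 48 h (on this read-out higher numbers stand for weaker inhibition of growth and lower numbers for stronger inhibition of growth), the highest of the two numbers measured so far. Among the measured compounds shown here, its only measured neighbour is compound 2 `COC(=O)[C@@]1(C)CCC=C2[C@@H]1CC[C@@H](C)[C@]2(C)Cc1c[nH]c2ccc(Br)cc12`, for which this assay gives 10000 nM; the step of a 1.4-fold lower number from compound 1 to compound 2 (0.15 log units; within the scatter) is the single comparison available, and it stays within the scatter. Compound 3 `COC(=O)[C@@]1(C)CCC=C2[C@@H]1CC[C@@H](C)[C@]2(C)Cc1c[nH]c2ccc(OC)cc12` is not yet measured. It differs from compound 1 by methoxy in place of methyl on an aromatic carbon. For the measured compounds named here, the bromo-for-methyl step at the same aromatic carbon is the only measured step that bears on this change, and it moved the number hardly at all. The methoxy-for-methyl exchange is therefore expected to give no step beyond the scatter, with at most a modest lowering of the number as the estimated step of a 1.2-fold lower number from compound 1 to compound 3 (0.07 log units; within the scatter). For compound 3 the estimated value in this assay is 12000 nM, with a range from 5000 nM to 30000 nM.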

Compound 3, concentration for 50% growth inhibition: 1200 nM
For compound 3 the middle estimate is 10-fold (1.00 log units) above the measured one, and the stated range ends above it.
By their numbers in this assay, from the lowest: compound 3; then compounds 2 and 1 (each within the scatter of the next).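

The methoxy group gives a 12-fold lower number from compound 1 to compound 3 (1.07 log units; beyond the scatter) in this assay and an 8.3-fold lower number from compound 2 to compound 3 (0.92 log units; beyond the scatter) at the same aromatic carbon, so the number at this position does depend on the group it carries. Compounds 1 and 2 lie within the scatter of each other, so the earlier comparison showed only that methyl and bromo are not separated here, not that the position is indifferent to substitution. Nothing available accounts for the distinct result with methoxy.

On these data alone, whether this result needs the whole methoxy group or only an oxygen on this carbon remains open, and a hydroxyl, an ethoxy or an amine here would test that. As far as these compounds go, all three compounds carry their group at this one place, so the effect of methoxy on other carbons of the ring also remains unknown.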